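A few compounds are considered here, and "the series" means these few. Any claim that something is new, unique, unknown or untested is made for them only; others in the source may bear on it.

Compound 3, with the structure `Cc1cc(C)c(Oc2cc(Nc3ccc(C#N)cc3)ncc2C(=O)NCc2cn(Cc3ccccc3F)nn2)c(C)c1`, gives in an ADME assay on MT4 cells (Homo sapiens) for cytotoxicity, read by MTT assay, with a stated time of 5 days (a lower number here means that less compound is tolerated, a higher number that more compound is tolerated), a value of > 222000 nM, which is a limit of the assay and not a number. Compound 1 `Cc1cc(C)c(Oc2cc(Nc3ccc(C#N)cc3)ncc2C(=O)NCc2cn(Cc3ccccc3[N+](=O)[O-])nn2)c(C)c1` also gives a limit in this assay, namely > 212000 nM. Compound 2 `Cc1ccc(Cn2cc(CNC(=O)c3cnc(Nc4ccc(C#N)cc4)cc3Oc3c(C)cc(C)cc3C)nn2)cc1` gives a measured number in this assay of 165000 nM. Among the three values shown, compound 3 therefore sits at a limit, and one further value is a limit as well.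

The new compound 4 has the structure `Cc1cccc(Cn2cc(CNC(=O)c3cnc(Nc4ccc(C#N)cc4)cc3Oc3c(C)cc(C)cc3C)nn2)c1`. It differs from compound 3 by the change (3-methylphenyl in place of 2-fluorophenyl on a saturated chain carbon bound to an aromatic nitrogen). Among the measured steps, the one that comes closest swaps a methylphenyl against a fluorophenyl in the same place: an at least 1.3-fold higher number from compound 2 to compound 3 (0.12 log units; that floor lies within the scatter). The related change an at least 1.2-fold lower number from compound 1 to compound 2 (0.10 log units; that floor lies within the scatter) is likewise small, and a step that the two limits leave unreadable from compound 1 to compound 3 stays unreadable. No step shown exceeds the usual scatter, so for compound 4 in this assay no change beyond that scatter is expected in either direction, and the estimated step is an at least 1.1-fold lower number from compound 3 to compound 4 (0.04 log units; that floor lies within the scatter). For compound 4 the expected value in this assay is 200000 nM, with a range estimated from 100000 nM to 400000 nM, and a limit rather than a number is likely.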

Compound 4, half-maximal cytotoxic concentration: 114000 nM
For compound 4 the middle estimate is 1.8-fold (0.24 log units) above the measured one; the range from low to high includes it.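

Among the compounds shown here, the step from 4-methylphenyl to 3-methylphenyl, on a saturated chain carbon bound to an aromatic nitrogen, is the first one here between two measured numbers in this assay, and it reads a 1.4-fold lower number from compound 2 to compound 4 (0.16 log units; within the scatter). Both methylphenyl compounds therefore give measured numbers, while the 2-nitrophenyl and 2-fluorophenyl compounds end at limits, and the two steps that start from those limits are floors only, an at least 1.9-fold lower number from compound 3 to compound 4 (0.28 log units; that floor lies within the scatter) and an at least 1.8-fold lower number from compound 1 to compound 4 (0.26 log units; that floor lies within the scatter). Compound 3 gives a limit of the assay and not a number: the limit of > 222000 nM in this assay, at which 1 of the 4 values shown sits.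

From the compounds shown here alone, how far compound 1 and compound 3 truly lie from compound 4 stays open, so the real size of those two steps could be larger than their floors show. The compounds shown also leave open what an amine or a carboxylic acid on the phenyl ring, or a longer chain in place of the single saturated chain carbon, would do to the tolerated concentration in this assay.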